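The compounds below may be only part of what the source reports. "The series", "measured", "known", "first", "only" and "open" are said of these compounds alone.

Measured so far in a physicochemical assay for solubility, read by turbidimetry, measured as kinetic solubility, at pH 7.4; a higher number here means a more soluble compound, a lower number a less soluble compound:
Compound 1 `COc1ccc(F)cc1N1C(=O)CSC1c1cccc(C(=O)NCCCCn2cccn2)c1`: 50000 nM
Compound 2 `COc1ccc(F)cc1N1C(=O)CSC1c1cccc(C(=O)NCCCCc2ccccc2)c1`: 10000 nM
Compound 3 `C#Cc1cc(C(=O)NCCCCc2ccccc2)cc(C2SCC(=O)N2c2ccccc2OC)c1`: 10000 nM

Compound 2, at 10000 nM, stands level with compound 3, and the two share the lowest number of the three. Compound 4 `Cc1cccc(N2C(=O)CSC2c2cccc(C(=O)NCCCCc3ccccc3)c2)c1` has 3-methylphenyl in place of 5-fluoro-2-methoxyphenyl on an amide-type nitrogen in a ring. Among the compounds with values here, no measured step touches that place. Within the data shown here, the one step available, a 5.0-fold lower number from compound 1 to compound 2 (0.70 log units; beyond the scatter), put phenyl in place of 1H-pyrazol-1-yl on the chain, so it shows only what size a single swap can reach in this assay. It gives no direction for this change, so no shift beyond the usual scatter is expected, and the expected step is no change at the digits printed from compound 2 to compound 4 (within the scatter). For compound 4 the estimate is 10000 nM, with an expected range from 4000 nM to 25000 nM.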

Compound 4, solubility: 10000 nM
Beside the measured number, compound 4's estimate shows no gap at the digits printed; measured number inside the range.
By their numbers in this assay, from the lowest: compounds 2, 3 and 4 (each within the scatter of the next); then compound 1.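

In this assay, putting 3-methylphenyl in place of 5-fluoro-2-methoxyphenyl on the amide-type nitrogen in the ring gives no change at the digits printed from compound 2 to compound 4 (within the scatter). Within the data shown here, this is the first measured step at this position, and it shows that this particular swap leaves the read-out within the scatter. No measured evidence here accounts for that result.

Still open, going by these compounds, is whether an amine or a carboxylic acid group at this position would shift the number. Also open, on these data alone, is whether 3-methylphenyl would give the same result alongside the 1H-pyrazol-1-yl chain of compound 1.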